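The compounds below may be only part of what the source reports. "The series", "measured", "known", "first", "only" and "open" are said of these compounds alone.

Compound 1 `O=C(Nc1ccccc1)c1cnc(NCc2c(F)ccc3c2CCO3)n2cnnc12` gives 4.1 in a physicochemical assay for lipophilicity, using the shake flask method, in phosphate buffer, measured as octanol-water partition, with a stated time of 30 min, at pH 7.4; a lower number here means a more polar compound, a higher number a more lipophilic compound; compound 2 `Cc1ncccc1-c1cnc(NCc2c(F)ccc3c2CCO3)n2c(=O)[nH]nc12` gives 3.

Compound 1 stands highest of the two numbers, with compound 2 lying lower by a gap beyond the scatter. For the measured compounds named here, no step between measured compounds that differ in one place is known here.

Compound 3 `C[C@@H]1CC(=O)N(c2cnc(NCc3c(F)ccc4c3CCO4)n3cnnc23)C1` differs from compound 1 by 4-methyl-2-oxopyrrolidin-1-yl in place of phenylcarbamoyl on an aromatic carbon. Going by the values given here, with no measured step to lean on, a downward step of moderate size is expected from compound 1 to compound 3, a number 1.10 log units lower from compound 1 to compound 3 (beyond the scatter). In this assay compound 3 is thus estimated at 3, within a range from 2.4 to 3.6.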

Compound 3, distribution coefficient: 1.8
For compound 3 the middle estimate is 1.20 log units above the measured one; the whole stated range lies above it.
By their numbers in this assay, from the lowest: compound 3; then compound 2; then compound 1.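

In this assay, putting 4-methyl-2-oxopyrrolidin-1-yl in place of phenylcarbamoyl on this aromatic carbon gives a number 2.30 log units lower from compound 1 to compound 3 (beyond the scatter), a large step. This shows that a change at this one position, with the rest of the core of compound 1 kept, can move the number widely. Nothing measured here accounts for the size of this step.

The compounds shown leave open which part of the exchange carries the step, the six-membered aromatic ring that leaves or the methyl on the ring that enters. As far as these compounds go, how an amine or a carboxylic acid on this aromatic carbon would read in this assay also stays open.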